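A bromothiophene in place of pyrazine on the amine carbon

The compounds below may be only part of what the source reports. "The series", "measured", "known", "first", "only" and "open" are said of these compounds alone.

Compound 1 `CCc1ccsc1CN[C@@H]1C[C@H]2C[C@@H]([C@H]1C)C2(C)C` and compound 2 `C[C@H]1[C@H](NCc2cnccn2)C[C@H]2C[C@@H]1C2(C)C` share one saturated core and differ in the aromatic group on the carbon bound to the amine nitrogen. In an ADME assay on MDCK cells (Canis lupus familiaris) for cytotoxicity, read by microscopy, with a stated time of 48 h (on this read-out lower numbers stand for higher toxicity in this test and higher numbers for lower toxicity in this test), compound 1 gives 25000 nM. In this assay compound 2 gives only a limit, > 100000 nM, so it stands at the limit of > 100000 nM in this assay, at which 1 of the 2 values shown sits, and no number is known for it. Compound 3 `C[C@H]1[C@H](NCc2sccc2Br)C[C@H]2C[C@@H]1C2(C)C` is not yet measured; it differs from compound 2 by 3-bromothiophen-2-yl in place of pyrazin-2-yl on a saturated chain carbon bound to an amine nitrogen. Among the measured compounds shown here, no measured pair differs in a single place, so the size of any step here rests on the two values alone. Compound 1 carries a substituted thiophene on the same carbon and gives 25000 nM. Compound 3 is therefore expected to move off the limit with a step of an at least 2.5-fold lower number from compound 2 to compound 3 (0.39 log units; beyond the scatter) toward higher toxicity. Compound 3 is estimated at 40000 nM, in a range from 15000 nM to 100000 nM.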

Compound 3, minimum cytotoxic concentration: 50000 nM
For compound 3 the middle estimate is 1.3-fold (0.10 log units) below the measured one, within the range that was stated.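

With 3-bromothiophen-2-yl in place of pyrazin-2-yl on a saturated chain carbon bound to an amine nitrogen, this assay shows an at least 2.0-fold lower number from compound 2 to compound 3 (0.30 log units; that floor lies within the scatter) and so gives this position its first direct reading. Compound 2 is a limit and not a number, which leaves that step only a floor: the limit of > 100000 nM in this assay, at which 1 of the 3 values shown sits. Bromo in place of ethyl on an aromatic carbon gives a 2.0-fold higher number from compound 1 to compound 3 (0.30 log units; within the scatter) and so the two substituted thiophenes cannot be told apart in this assay on the shared core.

Going by these compounds, it remains open how far compound 3 truly lies from compound 2. Also open, on these data alone, is whether an unsubstituted thiophene, a phenyl or a pyridine on the same carbon would sit with the thiophenes or with the pyrazine.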